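The source may hold more compounds than are shown below. What is called first, only, known or untested is meant among the compounds shown, and "the series" means these compounds.

The compounds here share one core, seen in compound 1 `CC(C)(C)OC(=O)N1CCN(C(=S)SCc2cn(Cc3ccc(Cl)cc3)nn2)CC1`, compound 2 `Cc1ccc(Cn2cc(CSC(=S)N3CCNCC3)nn2)cc1` and compound 3 `COc1ccc(-n2cc(CSC(=S)N3CCN(C(=O)OC(C)(C)C)CC3)nn2)cc1`. In a functional assay on ECa-109 cells (Homo sapiens) for inhibition, read by MTT assay, with a stated time of 72 h (a higher number here means a weaker inhibitor, a lower number a stronger inhibitor), compound 1 stops at a limit of the measurement, > 128000 nM. Compound 2 likewise gives only a limit in this assay, > 128000 nM. Compound 3 also reaches only a limit in this assay, > 128000 nM. So compound 3 stands exactly where the other two stand: no number has been read for it, only (the limit of > 128000 nM in this assay, at which 3 of the 3 values shown sit). Among the compounds with values here, the single measured step that changes one place, a step that the two limits leave unreadable from compound 1 to compound 3, therefore has no readable size, as both of its ends are limits.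

Compound 4 `Cc1ccc(Cn2cc(CSC(=S)N3CCN(C(=O)OC(C)(C)C)CC3)nn2)cc1` is the compound still to be measured, and it differs from compound 3 in one place: 4-methylbenzyl in place of 4-methoxyphenyl on an aromatic nitrogen. Within the data shown here, no measured step bears directly on this change. Compound 2, which carries the same 4-methylbenzyl group, sits at the limit, and every measured value here is a limit, so nothing shows a readable step in either direction. The step from compound 3 to compound 4 is expected to be a step that the limit leaves unreadable from compound 3 to compound 4, that is, nothing beyond the scatter. Compound 4 is thus estimated to give 200000 nM in this assay, with a range from 64000 nM to 600000 nM, most likely again reported only as a limit.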

Compound 4, half-maximal inhibitory concentration: 47900 nM
The estimate for compound 4 lay 4.2-fold (0.62 log units) above the measured number; the measured number lies below the stated range.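

In this assay, compound 4 is the only compound shown that gives a read number, so the group on the aromatic nitrogen can now be seen to matter: 4-methylbenzyl in place of 4-methoxyphenyl gives an at least 2.6-fold lower number from compound 3 to compound 4 (0.42 log units; beyond the scatter). Compound 4 also shows that two other places count, since tert-butoxycarbonyl in place of hydrogen on the amine nitrogen in the ring gives an at least 2.6-fold lower number from compound 2 to compound 4 (0.42 log units; beyond the scatter), and methyl in place of chloro on an aromatic carbon gives an at least 2.6-fold lower number from compound 1 to compound 4 (0.42 log units; beyond the scatter). Each of these sizes is only a minimum, as the other end of every step is a limit, and among these compounds a single change away from compound 4 returns to that limit: the limit of > 128000 nM in this assay, at which 3 of the 4 values shown sit.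

The step from 4-methoxyphenyl to 4-methylbenzyl changes both the carbon link to the ring and the group on the ring, so the compounds shown cannot separate the two, which a 4-methoxybenzyl group on the same nitrogen could do. From the compounds shown here alone, it also stays open whether the tert-butoxycarbonyl group can give way to a smaller acetyl group on the amine nitrogen.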